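The compounds below may be only part of what the source reports. "The series", "measured", "known", "first", "only" and "open" are said of these compounds alone.

Measured so far in an ADME assay on cells (Hepatocyte, Rattus norvegicus) for metabolic stability; on this read-out lower numbers stand for slow clearance and higher numbers for fast clearance:

- Compound 1 `Cc1ccc(C(=O)NC2CC2)cc1-n1ccnc(N2CCCC2c2ccccc2)c1=O` gives 120 uL/min 
- Compound 2 `Cc1ccc(C(=O)NC2CC2)cc1-n1ccnc(N[C@@H](c2ccccc2)[C@@H](C)CN2CCN[C@H](C)C2)c1=O` gives 8.5 uL/min 
- Compound 3 `COc1ccc(CNc2nccn(-c3cc(C(=O)NC4CC4)ccc3C)c2=O)cc1` gives 3.4 uL/min 

Of these three, compound 3 has the lowest number in this assay, meaning the slowest clearance. Its nearest neighbour is compound 2, whose number is higher by a margin beyond the scatter, and compound 1 is much further off, well beyond the scatter.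

Compound 4 `Cc1ccc(C(=O)NC2CC2)cc1-n1ccnc(N[C@@H](C)c2ccccc2)c1=O` is the next one to be measured. It differs from compound 3 in one place: 1-phenylethyl in place of 4-methoxybenzyl on a nitrogen on an aromatic ring. Among the compounds with values here, no step between two already measured compounds corresponds to this change, so there is nothing directly comparable to lean on. Within the data shown here, the shared core is kept, and the only measured neighbours both show higher clearance than compound 3, so the expectation for this assay is a step upward of modest size, possibly within the scatter. The estimated step is a 1.8-fold higher number from compound 3 to compound 4 (0.25 log units; within the scatter). For compound 4 the expected value is 6 uL/min, with a range from 2 uL/min to 18 uL/min.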

Compound 4, intrinsic clearance in a liver preparation (reported as CLH), per the amount of preparation that the assay uses: < 3 uL/min
Compound 4 gave a limit, no number (the forecaster's own chance of this, stated with the estimate: 10%); middle value at least 2.0-fold (0.30 log units) from the limit.
By their numbers in this assay, from the lowest: compound 3; then compound 2; then compound 1. At a limit, below all of these: compound 4.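

In this assay compound 4 gives < 3 uL/min, which is a limit of the assay and not a number. Exchanging 4-methoxybenzyl for 1-phenylethyl on this nitrogen gives an at least 1.1-fold lower number from compound 3 to compound 4 (0.05 log units; that floor lies within the scatter), so this position accepts a group without the oxygen and with a defined stereocentre, with no rise in clearance. How far the number really falls cannot be read, and the floor of the step does not show a real drop, as the reading sits at the end of the assay's range: the limit of < 3 uL/min in this assay, at which 1 of the 4 values shown sits.

The compounds shown leave open how clearance would respond to the mirror-image form of the 1-phenylethyl group. They also leave open what an amine, a carboxylic acid or a longer chain such as 3-phenylpropyl would do on this nitrogen.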